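The compounds below may be only part of what the source reports. "The series", "measured", "known", "first", "only" and "open" are said of these compounds alone.

Working notes on the series. Two compounds have a reading in a functional assay on CHO-K1 cells with Glucose-dependent insulinotropic receptor (Homo sapiens) as the target, read by a luciferase reporter, with a stated time of 5 h; a lower number here means a smaller maximal response, a higher number a larger maximal response: compound 1 `CS(=O)(=O)c1ccc(N2CCc3c(OC4CCN(C(=S)Sc5ccccc5)CC4)ncnc32)c(F)c1` gives 103% and compound 2 `CC(C)OC(=O)N1CCC(Oc2ncnc3c2CCN3c2ccc(S(C)(=O)=O)cn2)CC1` gives 111%. The two numbers sit within the usual scatter of each other, so no ordering between compound 2 and compound 1 can be drawn; compound 2 is simply one of two near-complete responses. Among the compounds with values here, the next compound, compound 3 `CC(C)OC(=O)N1CCC(Oc2ncnc3c2CCN3c2ccc([S+]([O-])N(C)C)cc2)CC1`, differs from compound 2 as follows: a group of 11 heavy atoms (8 carbon, 1 nitrogen, 1 oxygen, 1 sulfur; one six-membered aromatic ring of carbon only) in place of a group of 10 heavy atoms (6 carbon, 1 nitrogen, 2 oxygen, 1 sulfur; one six-membered aromatic ring with 1 hetero atom), on a nitrogen on an aromatic ring in a ring With no measured step of this kind available, the change is expected to move this assay little, if at all beyond the scatter, as a number 11 percentage points lower from compound 2 to compound 3 (beyond the scatter). Compound 3 is therefore estimated at 100%, between 75% and 120%.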

Compound 3, largest response reached (reported as percent of maximum), in percent of the reference or control that the assay uses: 128%
Beside the measured number, compound 3's estimate is 28 percentage points below it; the whole stated range lies below it.
By their numbers in this assay, from the lowest: compounds 1 and 2 (each within the scatter of the next); then compound 3.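

On a nitrogen on an aromatic ring in a ring, replacing 5-(methylsulfonyl)pyridin-2-yl with the group of compound 3, built on a six-membered aromatic ring of carbon only, gives a number 17 percentage points higher from compound 2 to compound 3 (beyond the scatter) in this assay. The position therefore accepts this change without loss of maximal response, though this rests on a single step. Nothing available accounts for the rise.

The ring and its sulfur-bearing substituent change together, so the compounds shown do not separate their contributions. Also open, from the compounds shown here alone, is whether an unsubstituted phenyl, or a phenyl carrying an amine or a carboxylic acid, on that nitrogen keeps the response.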